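The source may report more compounds than this note shows. Statements on the series, on what has been measured and on what is new or still open speak of the compounds shown alone.

In a functional assay on MDA-MB-231 cells (Homo sapiens) for inhibition, read by sulforhodamine B assay, with a stated time of 48 h (on this read-out lower numbers stand for stronger inhibition of growth and higher numbers for weaker inhibition of growth), two compounds have been measured so far:

Compound 1 `c1ccc(-c2nc3ncccn3c2CN2CCCCC2)cc1`: 30 nM
Compound 2 `c1ccc(-c2nc3ncccn3c2CN2CCNCC2)cc1`: 26700 nM

Compound 2 has the higher of the two numbers, so it is the weaker inhibitor of growth, and compound 1 lies far below it. The next compound, compound 3 `Cc1ccc(S(=O)(=O)N2CCN(Cc3c(-c4ccccc4)nc4ncccn34)CC2)cc1`, keeps all of compound 2 and changes one place: (4-methylphenyl)sulfonyl in place of hydrogen on an amine nitrogen in a ring. The new group, (4-methylphenyl)sulfonyl, sits on an amine nitrogen in a ring, the ring that already separates compound 2 from compound 1.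

Among the compounds with values here, only one measured step bears on this change: an 890-fold higher number from compound 1 to compound 2 (2.95 log units; beyond the scatter). It is a large step, and it shows that a change in this ring can move the number a long way in this assay. Within the data shown here, it says nothing direct about the new group, since no measured compound carries it. With compound 2 at the high end, a move down seems more likely than a move up, though probably not all the way to compound 1. The expected change is an 18-fold lower number from compound 2 to compound 3 (1.25 log units; beyond the scatter). For compound 3 the estimate is 1500 nM, with an expected range of 100 nM to 15000 nM.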

Compound 3, concentration for 50% growth inhibition: 12900 nM
Compound 3: the middle estimate sits 8.6-fold (0.93 log units) below what was measured; low and high end bracket the measured number.
By their numbers in this assay, from the lowest: compound 1; then compound 3; then compound 2.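

Placing (4-methylphenyl)sulfonyl on the amine nitrogen in the ring gives a 2.1-fold lower number from compound 2 to compound 3 (0.32 log units; beyond the scatter) in this assay and so adds a first fact about this nitrogen: it can carry a group of 10 heavy atoms without the number rising, and the move is modest but beyond the usual scatter. That move is small beside the large gap that separates the piperazin-1-yl and piperidin-1-yl compounds, since compound 3 at 12900 nM remains far above compound 1 at 30 nM in this read-out, so this substituent does not restore the low number seen with piperidin-1-yl. No measurement at hand explains either the size of this step or the remaining gap.

The compounds shown leave open which part of the new group matters, the sulfonyl link or its aromatic ring, and a methyl, an acetyl or a methanesulfonyl group on the same nitrogen would help to separate the two. They also leave open how a morpholin-4-yl ring in place of piperidin-1-yl would fall in this series.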